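The compounds below may be only part of what the source reports. "The series", "measured", "known", "first", "only" and "open" are said of these compounds alone.

Measured so far, in a functional assay on PC-3 cells (Homo sapiens) for inhibition, read by MTT assay, with a stated time of 72 h; on this read-out lower numbers stand for stronger inhibition and higher numbers for weaker inhibition:
Compound 1 `C#CCSc1nc(Nc2cccc(OC)c2)c2ccncc2n1` gives 17100 nM.
Compound 2 `CCCSc1nc(Nc2cccc(OC)c2)c2ccncc2n1` gives 15300 nM.
Compound 3 `C/C=C/Sc1nc(Nc2cccc(OC)c2)c2ccncc2n1` gives 6790 nM.

Compound 3 stands lowest of the three numbers, and since its distance to each of the other two lies beyond the scatter, it is the strongest inhibitor seen here. The nearest is compound 2, as the step of a 2.3-fold lower number from compound 2 to compound 3 (0.35 log units; beyond the scatter) shows; the furthest is compound 1, as the step of a 2.5-fold lower number from compound 1 to compound 3 (0.40 log units; beyond the scatter) shows. Both steps replace a chain on the sulfur with the prop-1-en-1-yl group, and both lowered the number by a modest amount. Between compound 1 and compound 2 the step of a 1.1-fold lower number from compound 1 to compound 2 (0.05 log units; within the scatter) stays within the scatter, so the propargyl and propyl chains cannot be told apart.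

Compound 4 `COc1cccc(Nc2nc(SCC3CC3)nc3cnccc23)c1` has not yet been measured. It differs from compound 3 in one place: cyclopropylmethyl in place of prop-1-en-1-yl on a sulfur. Within the data shown here, no measured step covers a cyclopropylmethyl group, so the expectation rests on the two steps above. They show the prop-1-en-1-yl group giving the lowest number of the three chains tried, while the other two sit together. Replacing it with a fourth chain is therefore expected to move the number back towards the region of compound 1 and compound 2, a modest rise estimated as a 1.8-fold higher number from compound 3 to compound 4 (0.25 log units; within the scatter). Compound 4 is estimated at 12000 nM, with a range from 6000 nM to 25000 nM.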

Compound 4, half-maximal inhibitory concentration: 14800 nM
Compound 4: middle estimate off by 1.2-fold (0.09 log units), on the low side, within the range that was stated.
By their numbers in this assay, from the lowest: compound 3; then compounds 4, 2 and 1 (each within the scatter of the next).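

In this assay the change from prop-1-en-1-yl to cyclopropylmethyl on the sulfur gives a 2.2-fold higher number from compound 3 to compound 4 (0.34 log units; beyond the scatter) and so loses the low number of compound 3. The new chain, with its three-membered ring of carbon, cannot be told apart from the two earlier chains, since both a 1.0-fold lower number from compound 2 to compound 4 (0.01 log units; within the scatter) and a 1.2-fold lower number from compound 1 to compound 4 (0.06 log units; within the scatter) stay within the scatter, and compound 3 now stands alone as the strongest of the four, with propyl, propargyl and cyclopropylmethyl forming one group at this position. No measurement shown here explains why prop-1-en-1-yl stands apart from the other three chains.

Going by these compounds, it remains open whether the lower number belongs to prop-1-en-1-yl alone or would also appear with a close relative such as allyl, where the double bond sits further along the chain. On these data alone, how a chain ending in an amine or a carboxylic acid, or a longer chain such as hexyl, would read at this sulfur also remains open.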